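The source may hold more compounds than are shown below. What is called first, only, known or untested is meant among the compounds shown, and "the series" means these compounds.

Measured in a functional assay on DU-145 cells (Homo sapiens) for inhibition, read by trypan blue exclusion, with a stated time of 96 h; on this read-out lower numbers stand for stronger inhibition of growth and higher numbers for weaker inhibition of growth:
- Compound 1 `Cc1ccc(S(=O)(=O)/C(=C/c2ccc(O)c([N+](=O)[O-])c2)C(=O)c2ccc(Cl)cc2)cc1` gives 25000 nM
- Compound 2 `Cc1ccc(S(=O)(=O)/C(=C/c2sccc2C)C(=O)c2ccc(Cl)cc2)cc1` gives 10000 nM
- Compound 3 `COc1ccccc1/C=C(\C(=O)c1ccc(Cl)cc1)S(=O)(=O)Cc1ccc(Cl)c(Cl)c1` gives 1000 nM

Compound 3 stands lowest of the three, so it shows the strongest growth inhibition in this assay. Compound 4 `COc1ccccc1/C=C(\C(=O)c1ccc(Cl)cc1)S(=O)(=O)c1ccc(C)cc1` has 4-methylphenyl in place of 3,4-dichlorobenzyl on a sulfonyl sulfur. Among the measured compounds shown here, no measured step covers this exchange. The only one, a 2.5-fold lower number from compound 1 to compound 2 (0.40 log units; beyond the scatter), is modest and lies at another place. Compound 1 and compound 2 both carry 4-methylphenyl and both have higher values than compound 3, though they also differ from it elsewhere. A moderate rise in the number is therefore expected, an estimated 5.0-fold higher number from compound 3 to compound 4 (0.70 log units; beyond the scatter). For compound 4 the estimated value is 5000 nM, with an expected range from 1500 nM to 15000 nM.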

Compound 4, concentration for 50% growth inhibition: 1000 nM
Compound 4: the middle estimate sits 5.0-fold (0.70 log units) above what was measured; the measured number lies below the stated range.
By their numbers in this assay, from the lowest: compounds 3 and 4 (each within the scatter of the next); then compound 2; then compound 1.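

In this assay the sulfonyl sulfur accepts the exchange of 3,4-dichlorobenzyl for 4-methylphenyl, with no change at the digits printed from compound 3 to compound 4 (within the scatter), so 4-methylphenyl alone does not account for the higher numbers of compound 1 and compound 2. With 4-methylphenyl held constant, 2-methoxyphenyl on the double-bonded chain carbon gives a 10-fold lower number from compound 2 to compound 4 (1.00 log units; beyond the scatter) and a 25-fold lower number from compound 1 to compound 4 (1.40 log units; beyond the scatter), which places the differences among these three compounds at that carbon. Going by these compounds, whether an amine or a carboxylic acid on the sulfonyl sulfur would keep this level remains open. No available evidence explains what these steps show.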